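A few compounds are considered here, and "the series" means these few. Any claim that something is new, unique, unknown or untested is made for them only; others in the source may bear on it.

Measured compounds:
- compound 1 `O=C(CN1CCN(c2cccc(F)c2)CC1)Nc1nc2c(s1)CCCC2`: > 10000 nM
- compound 2 `O=C(CN1CCN(c2ccc(F)cc2)CC1)Nc1nc2c(s1)CCCCC2`: 2000 nM

Both compounds were run in an assay on isolated protein for inhibition of long-chain fatty acid transport protein 1 (Mus musculus), read by scintillation counting, with a stated time of 20 min; on this read-out higher numbers stand for weaker inhibition and lower numbers for stronger inhibition. For compound 1 the result is only a limit of the assay, not a number: compound 1 gives > 10000 nM, and that is where it stands, at the limit of > 10000 nM in this assay, at which 1 of the 2 values shown sits. Compound 2 gives a measured number in this assay, namely 2000 nM. Among the measured compounds shown here, compound 2 differs from compound 1 in more than one place, so no single step between them is defined; the two values show only that compound 2 has a number while compound 1 sits at the limit.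

Compound 3 `O=C(CN1CCN(c2nccs2)CC1)Nc1nc2c(s1)CCCC2` has not yet been measured. It differs from compound 1 by 1,3-thiazol-2-yl in place of 3-fluorophenyl on an amine nitrogen in a ring. For the measured compounds named here, no measured pair among the compounds shows a change of this kind, so the expectation rests on where compound 1 stands. Because compound 1 gives > 10000 nM, compound 3 is expected to stay near the limit, and the step of an at least 1.1-fold lower number from compound 1 to compound 3 (0.04 log units; that floor lies within the scatter) is expected to be no larger than the scatter. Compound 3 is estimated at 9000 nM, within a range from 2500 nM to 30000 nM.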

Compound 3, half-maximal inhibitory concentration: 7900 nM
Estimate against measurement, compound 3: 1.1-fold (0.06 log units) above, and the stated range covers the measured number.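

Compound 1 gives > 10000 nM in this assay, which is a limit of the assay and not a number. With 1,3-thiazol-2-yl in place of 3-fluorophenyl on an amine nitrogen in a ring, the same core now carries a measured number, and the change gives an at least 1.2-fold lower number from compound 1 to compound 3 (0.10 log units; that floor lies within the scatter), so the step is known only by its floor, and that floor does not leave the scatter. This position therefore accepts a five-membered aromatic ring with 2 hetero atoms in place of a six-membered aromatic ring of carbon only and still gives a readable value, but the true size of the step cannot be fixed from one side alone: the limit of > 10000 nM in this assay, at which 1 of the 3 values shown sits.

Going by these compounds, whether the real number for compound 1 lies close to that of compound 3 or well away from it remains open, and so does whether this change would read the same on the core of compound 2. Also open, on these data alone, is what other groups on this nitrogen would give, such as pyridin-2-yl, an acetyl group or a plain methyl.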